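From methoxy to ethoxy on a shared core

The source may report more compounds than this note shows. Statements on the series, on what has been measured and on what is new or still open speak of the compounds shown alone.

Measured so far:
compound 1 `CC(=O)/C=C/c1cccc(F)c1O` gives 51200 nM
compound 2 `COc1cccc(/C=C/C(C)=O)c1O` gives 3250 nM

These numbers come from a functional assay for inhibition, with Oryctolagus cuniculus as the target (a higher number here means a weaker inhibitor, a lower number a stronger inhibitor), and compound 2 stands lowest of the two, so it is the stronger inhibitor, by a gap beyond the usual scatter. Among the compounds with values here, that gap is the one measured step, a 16-fold lower number from compound 1 to compound 2 (1.20 log units; beyond the scatter) with methoxy in place of fluoro on an aromatic carbon. Next comes compound 3 `CCOc1cccc(/C=C/C(C)=O)c1O` and its change from compound 2 is methyl in place of hydrogen on a saturated chain carbon bound to an oxygen on an aromatic ring in words, methyl in place of hydrogen on a saturated chain carbon bound to an oxygen on an aromatic ring, or methoxy to ethoxy.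

Within the data shown here, the step of a 16-fold lower number from compound 1 to compound 2 (1.20 log units; beyond the scatter) is the only evidence at hand, and it swapped one group for a quite different one, so its large size says little about this smaller edit. Among the measured compounds shown here, no measured compound shows how ethoxy compares with methoxy. The expected change is modest, an estimated 1.3-fold lower number from compound 2 to compound 3 (0.11 log units; within the scatter) and perhaps no more than the scatter. For compound 3 the estimate in this assay is 2500 nM with an expected range from 800 nM to 8000 nM in repeat measurements.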

Compound 3, half-maximal inhibitory concentration: 3310 nM
The estimate for compound 3 lay 1.3-fold (0.12 log units) below the measured number; measured number inside the range.
By their numbers in this assay, from the lowest: compounds 2 and 3 (each within the scatter of the next); then compound 1.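

In this assay the step to the ethoxy group is a 1.0-fold higher number from compound 2 to compound 3 (0.01 log units; within the scatter) and so the two numbers cannot be told apart, which means that this place on the shared core accepts one extra methyl on the saturated chain carbon bound to an oxygen on an aromatic ring with no measurable cost or gain. The step of a 15-fold lower number from compound 1 to compound 3 (1.19 log units; beyond the scatter) is large and beyond the scatter, just as the step from fluoro to methoxy was, so among these compounds the large gap from compound 1 is not unique to methoxy but appears with ethoxy as well. No measurement on these compounds offers an explanation for either result.

Going by these compounds, two groups of this kind cannot show how far the tolerance extends, so it remains open whether a longer chain such as propoxy, a branched isopropoxy or a bulkier benzyloxy group would keep the number in the same range. On these data alone, it is also open whether the oxygen itself matters, a question that a plain ethyl group or an amine at the same place could address.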